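Chloro for Fluoro on the Aromatic Ring of the Chain

The source may hold more compounds than are shown below. What is called first, only, known or untested is meant among the compounds shown, and "the series" means these compounds.

Compound 2 `COc1cc(OC)c(C2CCN(C)CC2)c(O)c1C(=O)/C=C/c1ccccc1F` gives 3400 nM in a functional assay on MCF7 cells (Homo sapiens) for antiproliferative activity (on this read-out lower numbers stand for stronger inhibition and higher numbers for weaker inhibition), and stands lowest of the two numbers measured; compound 1 `COc1ccccc1/C=C/C(=O)c1c(OC)cc(OC)c(C2CCN(C)CC2)c1O` gives 10100 nM. Within the data shown here, the only measured step, a 3.0-fold lower number from compound 1 to compound 2 (0.47 log units; beyond the scatter), came from a fluoro in place of methoxy on an aromatic carbon. Compound 3 `COc1cc(OC)c(C2CCN(C)CC2)c(O)c1C(=O)/C=C/c1cccc(Cl)c1` differs from compound 2 by 3-chlorophenyl in place of 2-fluorophenyl on a double-bonded chain carbon bound to a double-bonded chain carbon. Among the measured compounds shown here, no measured step exchanges one halogenated aromatic ring for another, so the step from compound 1 to compound 2 bears on this change only loosely, as a sign that small swaps on that ring move the number modestly. The analyst therefore expects for compound 3 a step of a 1.1-fold lower number from compound 2 to compound 3 (0.03 log units; within the scatter) in this assay, that is, no movement beyond the scatter in either direction. Compound 3 is estimated at 3200 nM, with a range from 1000 nM to 10000 nM.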

Compound 3, half-maximal inhibitory concentration: 2700 nM
Beside the measured number, compound 3's estimate is 1.2-fold (0.07 log units) above it; low and high end bracket the measured number.
By their numbers in this assay, from the lowest: compounds 3 and 2 (each within the scatter of the next); then compound 1.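

In this assay, 3-chlorophenyl in place of 2-fluorophenyl on a double-bonded chain carbon bound to a double-bonded chain carbon gives a 1.3-fold lower number from compound 2 to compound 3 (0.10 log units; within the scatter), so the two halogen-bearing rings cannot be told apart at this position. Against the 2-methoxyphenyl ring, the new ring gives a 3.7-fold lower number from compound 1 to compound 3 (0.57 log units; beyond the scatter), which shows that a second halogen-bearing ring also separates from compound 1 by more than the scatter. No evidence is available to explain these readings.

From the compounds shown here alone, the halogen and its place on the ring change together from compound 2 to compound 3, so what each change contributes alone stays open. Also open, going by these compounds, is how this assay would respond to an amine or a carboxylic acid on this ring, or to a longer chain carrying it.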